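The source may report more compounds than this note shows. Statements on the series, on what has been measured and on what is new or still open speak of the compounds shown alone.

In a functional assay on cells (Platelet, Homo sapiens) for inhibition (on this read-out lower numbers stand for stronger inhibition and higher numbers for weaker inhibition), compound 1 (`CCOC(=O)c1cccc(-c2n[nH]c3ccccc23)c1`) gives 5650 nM while compound 2 (`COC(=O)c1ccc(-c2nn(Cc3ccccc3)c3ccccc23)cc1`) gives 560 nM and so holds the lower of the two numbers, a gap beyond the usual scatter. Compound 3 (`CC(C)OC(=O)c1ccc(-c2nn(Cc3ccccc3)c3ccccc23)cc1`) matches compound 2 except for one swap: isopropyl in place of methyl on an oxygen next to a carbonyl group. Going by the values given here, no measured pair shows this kind of change on its own, so any forecast is uncertain. The expected change is a 1.3-fold higher number from compound 2 to compound 3 (0.10 log units; within the scatter), a higher number meaning weaker inhibition. For compound 3 the estimated value is 700 nM with 250 nM to 2500 nM as the expected range.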

Compound 3, half-maximal inhibitory concentration: > 10000 nM
Compound 3: no number, only a limit; the forecaster's own chance of this, stated with the estimate: 5%; middle value at least 14-fold (1.15 log units) away from the limit.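

Until now, nothing showed how this position responds to a change. In this assay, isopropyl in place of methyl on an oxygen next to a carbonyl group gives a clear loss of inhibition (an at least 17-fold higher number from compound 2 to compound 3 (1.25 log units; beyond the scatter)), so even this small swap matters here. As far as these compounds go, the value of compound 3 is a limit of the assay and not a number, so the full size of the loss stays unknown: the limit of > 10000 nM in this assay, at which 1 of the 3 values shown sits.

The compounds shown leave open whether ethyl on this oxygen would keep the inhibition of compound 2 or lose it. They also leave open how a carboxylic acid or an amide in place of methoxycarbonyl would behave.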